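The source may hold more compounds than are shown below. What is called first, only, known or untested is meant among the compounds shown, and "the series" means these compounds.

Measured compounds, each with its largest response in a functional assay on isolated protein for inhibition of Glucose-dependent insulinotropic receptor (Rattus norvegicus), read by HTRF and cAMP accumulation; a lower number here means a smaller maximal response, a higher number a larger maximal response:

compound 1 `Cc1nc(S(C)(=O)=O)ccc1Oc1ncnc(OC2CCN(C(=O)OC(C)(C)CF)CC2)c1F` — 95%
compound 2 `Cc1nc(S(C)(=O)=O)ccc1Oc1ncnc(OC2CCN(C(=O)O[C@@H](C)CF)CC2)c1F` — 84%
compound 3 `Cc1nc(S(C)(=O)=O)ccc1Oc1ncnc(OC2CCN(C(=O)OC3(C(F)(F)F)COC3)CC2)c1F` — 84%

Among these three, compound 1 stands highest in this assay: the steps of a number 11 percentage points lower from compound 1 to compound 2 (beyond the scatter) and a number 11 percentage points lower from compound 1 to compound 3 (beyond the scatter) both lie beyond the scatter, while no change at the digits printed from compound 2 to compound 3 (within the scatter) lies within it. Compound 4 `Cc1nc(S(C)(=O)=O)ccc1Oc1ncnc(OC2CCN(C(=O)SC3CC3)CC2)c1F` differs from compound 1 at the same carbonyl: a group of 4 heavy atoms (3 carbon, 1 sulfur; one three-membered non-aromatic ring of carbon only) in place of a group of 6 heavy atoms (4 carbon, 1 oxygen, 1 fluorine; no ring), on a carbonyl carbon. Both measured steps swapped the group on the oxygen next to the carbonyl and each lowered the response modestly, so a change of similar size at that carbonyl is expected here too, downward rather than upward. Compound 4 is therefore estimated at 84%, within 72% to 96%, meaning an expected step of a number 11 percentage points lower from compound 1 to compound 4 (beyond the scatter).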

Compound 4, largest response reached (reported as efficacy), in percent of the reference or control that the assay uses: 80%
Compound 4: the middle estimate sits 4 percentage points above what was measured, within the range that was stated.
By their numbers in this assay, from the lowest: compounds 4, 2 and 3 (each within the scatter of the next); then compound 1.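

In this assay, a group carrying sulfur and a three-membered carbon ring on the carbonyl carbon also gives a lower maximal response than the group in compound 1 (a number 15 percentage points lower from compound 1 to compound 4 (beyond the scatter)). Its response cannot be told apart from those of the other two replacements (a number 4 percentage points lower from compound 3 to compound 4 (within the scatter); a number 4 percentage points lower from compound 2 to compound 4 (within the scatter)), although these groups differ in size and atoms. Nothing available explains this result.

Still open, as far as these compounds go, is whether the sulfur or the ring sets the response, and how an amine on the carbonyl carbon, or a longer carbon chain on the sulfur, would read.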